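From trifluoromethyl to ethoxycarbonyl on a carbonyl carbon

This account rests on a few compounds, and the source may have more. Where it says the series, first, only, none or still open, it means among the compounds named here.

Going by the values given here, in a functional assay on the whole organism with Rattus norvegicus as the target (a higher number here means that more compound is needed for the effect, a lower number that less compound is needed), compound 1 (`CCOC(=O)C(=O)Nc1nc(-c2ccc(O)cc2)cs1`) gives about 15 mg/kg and compound 2 (`CCOC(=O)C(=O)Nc1nc(-c2ccc(NC(=O)C(F)(F)F)cc2)cs1`) gives about 1 mg/kg as the lower of the two numbers so far. Among the compounds with values here, the only measured step runs a 15-fold lower number from compound 1 to compound 2 (1.18 log units; beyond the scatter) and is large, beyond the scatter, with ((trifluoromethyl)carbonyl)amino in place of hydroxy on an aromatic carbon. Compound 3 (`CCOC(=O)C(=O)Nc1ccc(-c2csc(NC(=O)C(=O)OCC)n2)cc1`) differs from compound 2 by ethoxycarbonyl in place of trifluoromethyl on a carbonyl carbon. The same difference reads ((ethoxycarbonyl)carbonyl)amino in place of ((trifluoromethyl)carbonyl)amino. Within the data shown here, no measured step makes this change, so the evidence is indirect and the uncertainty wide. Compound 3 keeps the amide-type nitrogen and carbonyl that compound 2 carries in place of hydroxy, so it is expected to stay nearer compound 2 at about 1 mg/kg than compound 1 at about 15 mg/kg and to rise only a little. The estimated small rise is a 2.0-fold higher number from compound 2 to compound 3 (0.30 log units; within the scatter) and lies at the edge of the scatter. For compound 3 the estimate is 2 mg/kg with 0.5 mg/kg to 8 mg/kg as its expected range.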

Compound 3, dose for half-maximal effect: > 30 mg/kg
Compound 3: no number, only a limit; the forecaster's own chance of this, stated with the estimate: 5%; middle value at least 15-fold (1.17 log units) from the limit.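

In this assay the result for compound 3 is a limit of the assay and not a number: the limit of > 30 mg/kg in this assay, at which 1 of the 3 values shown sits.

The group on the carbonyl carbon whose other neighbour is the amide-type nitrogen proves decisive here: ethoxycarbonyl in place of trifluoromethyl gives an at least 30-fold higher number from compound 2 to compound 3 (1.47 log units; beyond the scatter), so keeping that nitrogen and carbonyl does not by itself preserve the low dose seen with trifluoromethyl. Measured against the hydroxy compound, the new group gives an at least 2.0-fold higher number from compound 1 to compound 3 (0.30 log units; that floor lies within the scatter), so the large drop in dose that ((trifluoromethyl)carbonyl)amino brought in place of hydroxy does not carry over to ((ethoxycarbonyl)carbonyl)amino, although this floor does not separate the two compounds beyond the scatter.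

Going by these compounds, the size of the step remains open, since the true number for compound 3 cannot be read past its limit. With only trifluoromethyl and ethoxycarbonyl shown on this carbonyl carbon, it also remains open whether a methyl, an amine or a carboxylic acid there would stay close to compound 2 or move towards compound 3.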